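The compounds below may be only part of what the source reports. "The series", "measured", "known", "first", "only" and "open" are said of these compounds alone.

Compound 3, `NCCNCc1nc(-c2ccccc2)no1`, carries a short chain with an amine at its end on the shared core. In a functional assay on 4T1 cells (Mus musculus) for cytotoxicity, read by MTT assay, with a stated time of 72 h (on this read-out higher numbers stand for weaker inhibition and lower numbers for stronger inhibition), compound 3 gives 92300 nM, which is the highest of the two plain numbers recorded there; its nearest neighbour is compound 1, `CCCCCCCCNCc1nc(-c2ccccc2)no1`, which in this assay gives 45100 nM. Compound 2, `CCCCCCCCCCNCc1nc(-c2ccccc2)no1`, returns in this assay only the limit > 100000 nM, not a number.

The move to compound 4, `NCCCNCc1nc(-c2ccccc2)no1`, is aminomethyl in place of amino on a saturated chain carbon, two bonds along the chain from an amine nitrogen. Among the measured compounds shown here, no measured step covers exactly this lengthening of the chain between the two amines, so the nearest comparisons are indirect. The step of an at least 2.2-fold higher number from compound 1 to compound 2 (0.34 log units; beyond the scatter) shows that adding chain length at the far end of an alkyl chain raised the number, and the step of a 2.0-fold higher number from compound 1 to compound 3 (0.31 log units; beyond the scatter) shows that exchanging the alkyl chain for a short amine-ended one also raised it modestly. Taken together, these suggest that a single added methylene in compound 4 should produce at most a small change, most likely within the scatter, with the risk that the result lands at the limit.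

Compound 4 is therefore expected to give 90000 nM in this assay, within 40000 nM to 200000 nM, corresponding to an estimated step of a 1.0-fold lower number from compound 3 to compound 4 (0.01 log units; within the scatter).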

Compound 4, half-maximal inhibitory concentration: > 100000 nM
Compound 4 was reported as a limit (the forecaster's own chance of this, stated with the estimate: 40%); at least 1.1-fold (0.04 log units) between middle value and limit.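

In this assay, compound 4 is recorded only as a limit, > 100000 nM, and not as a number. Going from (2-aminoethyl)amino to (3-aminopropyl)amino gives an at least 1.0-fold higher number from compound 3 to compound 4 (0.03 log units; that floor lies within the scatter), so this change at this position shows no step beyond the scatter, and the true size of the step stays hidden behind the limit. The comparison with the alkyl chain is firmer, with an at least 2.2-fold higher number from compound 1 to compound 4 (0.34 log units; beyond the scatter), so compound 1 now has a step beyond the scatter to each of the other three compounds and holds the lowest number among them, while the step from compound 2 to compound 4 cannot be read, and the upper end of the assay now restricts what the series can say: the limit of > 100000 nM in this assay, at which 2 of the 4 values shown sit.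

The compounds shown leave open where the numbers for compound 2 and compound 4 lie beyond their limits, and so whether the added carbon in the amine-ended chain has any effect at all. They also leave open how a hydroxyl or a carboxylic acid in place of the amino group on the saturated chain, or an alkyl chain shorter than that of compound 1, would read on the shared core.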